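The source may hold more compounds than are shown below. What is called first, only, known or untested is meant among the compounds shown, and "the series" means these compounds.

Three amides sharing one core have been measured in a functional assay on KG-1 cells (Homo sapiens) for cytotoxicity, read by luminescence and CellTiter-Glo, with a stated time of 3 days; a higher number here means a weaker inhibitor, a lower number a stronger inhibitor. Compound 1 `N#Cc1ccc(NC(=O)c2cc(Br)ccc2O)cc1` gives 1290 nM, compound 2 `N#Cc1ccc(NC(=O)c2cc(-c3cccnc3)ccc2O)cc1` gives 8330 nM, and compound 3 `N#Cc1ccc(NC(=O)c2ccccc2O)cc1` gives 5370 nM. Compound 3 thus stands second highest of the three numbers, separated from compound 2 by a 1.6-fold lower number from compound 2 to compound 3 (0.19 log units; within the scatter) and from compound 1 by a 4.2-fold higher number from compound 1 to compound 3 (0.62 log units; beyond the scatter). Compound 4 `N#Cc1ccc(NC(=O)c2cc(C(F)(F)F)ccc2O)cc1` differs from compound 3 by trifluoromethyl in place of hydrogen on an aromatic carbon. The step that bears most on this is a 4.2-fold higher number from compound 1 to compound 3 (0.62 log units; beyond the scatter), since the hydrogen compound 3 gained there is now exchanged for trifluoromethyl; the change a 6.5-fold higher number from compound 1 to compound 2 (0.81 log units; beyond the scatter) shows that a larger replacement gave a higher number instead. A modest move toward a lower number is therefore expected, a 2.4-fold lower number from compound 3 to compound 4 (0.39 log units; beyond the scatter). Compound 4 is estimated at 2200 nM, within 900 nM to 5500 nM.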

Compound 4, half-maximal inhibitory concentration: 4810 nM
Beside the measured number, compound 4's estimate is 2.2-fold (0.34 log units) below it; the range from low to high includes it.
By their numbers in this assay, from the lowest: compound 1; then compounds 4, 3 and 2 (each within the scatter of the next).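

In this assay, trifluoromethyl on this aromatic carbon, para to a hydroxy group, cannot be told apart from hydrogen (a 1.1-fold lower number from compound 3 to compound 4 (0.05 log units; within the scatter)) or from pyridin-3-yl (a 1.7-fold lower number from compound 2 to compound 4 (0.24 log units; within the scatter)), while bromo stays clearly apart from it (a 3.7-fold higher number from compound 1 to compound 4 (0.57 log units; beyond the scatter)). Of the four groups at this position, only the bromo of compound 1 separates from the others, so replacing hydrogen does not by itself shift the number. Nothing available explains this difference between bromo and trifluoromethyl. On these data alone, whether chloro, an amine or a carboxylic acid at this place would match bromo or the other three remains open.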